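A few compounds are considered here, and "the series" means these few. Any claim that something is new, unique, unknown or untested is made for them only; others in the source may bear on it.

Two compounds share the core. Compound 1 `COc1ccc(Nc2ncnc3cc(OC)c(OCCCCC(=O)Nc4ccc(S(N)(=O)=O)cc4)cc23)cc1OC` gives 35400 nM in a functional assay on A-431 cells (Homo sapiens) for antiproliferative activity, read by MTT assay, with a stated time of 72 h; on this read-out lower numbers stand for stronger inhibition and higher numbers for weaker inhibition. Compound 2 `COc1cc2ncnc(Nc3ccc(C)cc3)c2cc1OCCCCC(=O)Nc1ccc(S(N)(=O)=O)cc1` gives 35500 nM in this assay, and the step of a 1.0-fold higher number from compound 1 to compound 2 (0.00 log units; within the scatter) leaves the two numbers within the scatter of each other, so compound 2 sits level with compound 1 on the numbers shown. Compound 3 `CCc1ccc(Nc2ncnc3cc(OC)c(OCCCCC(=O)Nc4ccc(S(N)(=O)=O)cc4)cc23)cc1` is not yet measured and differs from compound 2 by methyl in place of hydrogen on a saturated chain carbon bound to an aromatic carbon. Going by the values given here, the only measured step, a 1.0-fold higher number from compound 1 to compound 2 (0.00 log units; within the scatter), touches the same aryl group and was flat, so no movement beyond the scatter is expected in this assay. The expected step is a 1.0-fold lower number from compound 2 to compound 3 (0.01 log units; within the scatter). Compound 3 is estimated at 35000 nM, within 15000 nM to 80000 nM.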

Compound 3, half-maximal inhibitory concentration: 7220 nM
Compound 3: the middle estimate sits 4.8-fold (0.69 log units) above what was measured; measured number below the stated range.
By their numbers in this assay, from the lowest: compound 3; then compounds 1 and 2 (each within the scatter of the next).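

In this assay, the aryl group on the nitrogen proves responsive after the flat first pair: 4-ethylphenyl in place of 4-methylphenyl gives a 4.9-fold lower number from compound 2 to compound 3 (0.69 log units; beyond the scatter). Against the 3,4-dimethoxyphenyl group, 4-ethylphenyl gives a 4.9-fold lower number from compound 1 to compound 3 (0.69 log units; beyond the scatter), so a single added methyl on the saturated chain carbon bound to an aromatic carbon separates compound 3 from compound 2. Nothing available explains this step. Still open, as far as these compounds go, is whether a longer chain such as propyl lowers the number further, and how a branched chain such as isopropyl or an amine at the same place would read.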